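This account rests on a few compounds, and the source may have more. Where it says the series, first, only, none or still open, it means among the compounds named here.

For the measured compounds named here, only two compounds have a measured value so far in a functional assay on NCI-H460 cells (Homo sapiens) for inhibition, read by MTT assay, with a stated time of 24 h, tested at 100 ug/mL (a lower number here means less inhibition of growth, a higher number more inhibition of growth at the concentration tested), and they lie well apart. Compound 1 `O=C(CCCCC(S)CCS)NO` gives 43.7% as the lower of the two numbers, while compound 2 `O=C(CCCCC1CCSS1)Nc1ccc(OC(F)(F)F)cc1` reaches 83% and the gap between them lies beyond the usual scatter. These two differ in more than one place, so the gap cannot be pinned on any single change.

Compound 3 `O=C(CCCCC(S)CCS)Nc1ccccc1` keeps the chain of compound 1 and changes only the end group, with phenyl in place of hydroxy on an amide-type nitrogen. Going by the values given here, no measured pair shows this change on its own, so any forecast is tentative. Among the compounds with values here, the one hint comes from compound 2, which at 83% also carries a six-membered aromatic ring of carbon only on an amide-type nitrogen, and this single example points upward. In this assay a moderate rise is therefore expected, probably but not certainly beyond the scatter, and the estimated step is a number 21.3 percentage points higher from compound 1 to compound 3 (beyond the scatter) in that direction. For compound 3 the estimated value is 65% (expected range 45% to 85%).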

Compound 3, percent growth inhibition at one concentration: 25.4%
Compound 3: the middle estimate sits 39.6 percentage points above what was measured; measured number below the stated range.
By their numbers in this assay, from the lowest: compound 3; then compound 1; then compound 2.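

In this assay, phenyl in place of hydroxy on an amide-type nitrogen can now be read on its own, with the rest of the molecule held constant: the change gives a number 18.3 percentage points lower from compound 1 to compound 3 (beyond the scatter). On this open chain with its two thiol groups, hydroxy at this position therefore goes with more growth inhibition than phenyl, and a six-membered aromatic ring of carbon only on this nitrogen does not by itself raise the number. No independent measurement among the data shown explains why the number falls with this change.

The compounds shown leave open whether this step is specific to phenyl or would also appear with other groups on the same nitrogen, such as a methyl group, a benzyl group or a pyridine ring. They also leave open whether a trifluoromethoxy group on the phenyl ring of compound 3 would change the number, and whether swapping phenyl and hydroxy on the chain end found in compound 2 would give a step of the same direction and size.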